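Swapping the aryl ring on the piperazine of compounds tested against a T-type channel

A few compounds are considered here, and "the series" means these few. Any claim that something is new, unique, unknown or untested is made for them only; others in the source may bear on it.

Of the compounds shown here, three sharing one core have been measured in an assay on HEK293 cells for inhibition of Voltage-dependent T-type calcium channel subunit alpha-1G (Homo sapiens), read by fluorescence, tested at 10 uM; on this read-out lower numbers stand for less inhibition and higher numbers for more inhibition at the one concentration tested (going by the name of the read-out). Compound 1 `CCCc1nc(-c2ccccc2)c(CNCCCN2CCN(c3ccc(F)cc3)CC2)o1` gives 62.5%. Compound 2 `CCCc1nc(-c2ccccc2)c(CNCCCN2CCN(c3cccc(C(F)(F)F)c3)CC2)o1` gives 51.6%. Compound 3 `CCCc1nc(-c2ccccc2)c(CNCCCN2CCN(c3ccc(OC)cc3)CC2)o1` gives 42.1%, the lowest of the three numbers; its gap to compound 2 lies within the scatter, while the step of a number 20.4 percentage points lower from compound 1 to compound 3 (beyond the scatter) lies beyond it. Compound 4 `CCCc1nc(-c2ccccc2)c(CNCCCN2CCN(c3ccccc3Cl)CC2)o1` is not yet measured. It differs from compound 3 as follows: 2-chlorophenyl in place of 4-methoxyphenyl on an amine nitrogen in a ring.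

Among the measured compounds shown here, no measured step introduces a chloro group or a 2-substituted ring, so the only guidance comes from the steps that removed the methoxy ring: a number 20.4 percentage points lower from compound 1 to compound 3 (beyond the scatter) and a number 9.5 percentage points lower from compound 2 to compound 3 (within the scatter), the second within the scatter. Both rings without methoxy gave numbers at or above that of compound 3, so a modest rise is expected, with real uncertainty about its size. Compound 4 is therefore estimated at 52%, within 35% to 68%, which means an expected step of a number 9.9 percentage points higher from compound 3 to compound 4 (within the scatter) in this assay.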

Compound 4, a percentage reported as inhibition, at one concentration (the size of the read-out at that concentration, not a potency): 64.7%
Compound 4: the middle estimate sits 12.7 percentage points below what was measured, and the stated range covers the measured number.
By their numbers in this assay, from the lowest: compounds 3 and 2 (each within the scatter of the next); then compounds 1 and 4 (each within the scatter of the next).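

Placing a 2-chlorophenyl ring on this ring nitrogen gives a step of a number 22.6 percentage points higher from compound 3 to compound 4 (beyond the scatter) against the 4-methoxyphenyl ring and of a number 13.1 percentage points higher from compound 2 to compound 4 (beyond the scatter) against the 3-(trifluoromethyl)phenyl ring, so this position accepts a chloro-bearing ring without any loss against those two. Among the compounds shown here, the change from 4-fluorophenyl, a number 2.2 percentage points higher from compound 1 to compound 4 (within the scatter), shows that two differently substituted rings can give the same reading here, which the earlier compounds could not show. Nothing available explains why these rings differ in this way.

Still open, from the compounds shown here alone, is whether the result depends on the chloro group itself or on where it sits on the ring, a question that a 3-chlorophenyl or 4-chlorophenyl ring would help to answer. A 2-methoxyphenyl ring would likewise show whether the methoxy group keeps its lower reading at that other ring position.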